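Widening the Acid-Bearing Ring: Expected Solubility of Compound 4

This account rests on a few compounds, and the source may have more. Where it says the series, first, only, none or still open, it means among the compounds named here.

Compound 1 `CCNC(=O)Nc1nc2cc(-c3ccc(C(=O)O)nc3)cc(-c3ccccn3)c2s1` is the starting point of the set. In a physicochemical assay for solubility, read by turbidimetry, in phosphate buffer, with a stated time of 24 h, at pH 7.4 (on this read-out lower numbers stand for lower solubility and higher numbers for higher solubility), compound 1 gives 50 ug/mL. Compound 2 `CCNC(=O)Nc1nc2cc(-c3cnc(N4CCC(C)(C(=O)O)CC4)nc3)cc(-c3ccccn3)c2s1` carries a 4-carboxy-4-methylpiperidin-1-yl group on an aromatic carbon between two ring nitrogen atoms. In this assay compound 2 reaches only a limit, > 800 ug/mL. Compound 3 `CCNC(=O)Nc1nc2cc(-c3cncc(N4CCC(C)(C(=O)O)CC4)c3)cc(-c3ccccn3)c2s1` likewise gives only a limit, > 800 ug/mL. Compound 2 thus stands at the limit of > 800 ug/mL in this assay, at which 2 of the 3 values shown sit, without a number of its own. Compound 4 `CCNC(=O)Nc1nc2cc(-c3cnc(N4CCCC(C)(C(=O)O)CC4)nc3)cc(-c3ccccn3)c2s1` differs from compound 2 by 4-carboxy-4-methylazepan-1-yl in place of 4-carboxy-4-methylpiperidin-1-yl on an aromatic carbon. Among the compounds with values here, no measured pair with a single change of this kind exists here, so the step is expected to be small, within the scatter, in either direction. Compound 4 is therefore expected to give about 800 ug/mL, within 400 ug/mL to 1600 ug/mL. That expectation corresponds to a step of a number no higher from compound 2 to compound 4 (the limit leaves the size open), most likely reported again only as a limit.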

Compound 4, solubility: > 800 ug/mL
Compound 4 gave a limit, no number (the forecaster's own chance of this, stated with the estimate: 65%); the middle value sits exactly at the limit.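

In this assay, compound 2 and compound 4 each give only a limit, so no step can be read between them. The compounds shown leave open whether 4-carboxy-4-methylazepan-1-yl in place of 4-carboxy-4-methylpiperidin-1-yl changes solubility at all.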